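The source may report more compounds than this note shows. Statements on the series, on what has been measured and on what is new or still open speak of the compounds shown alone.

Measured so far in a functional assay on MDA-MB-231 cells (Homo sapiens) for cytotoxicity, read by MTT assay, with a stated time of 48 h; on this read-out higher numbers stand for weaker inhibition and lower numbers for stronger inhibition:

Compound 1, `Fc1cccc(Nc2nc(-c3cccc(F)c3)nc3ccc(F)cc23)c1`: compound 1 gives 47600 nM.
Compound 2, `Fc1cccc(-c2nc(Nc3ccc(Br)cc3)c3cc(F)ccc3n2)c1`: compound 2 gives only a limit of the assay, > 50000 nM.
Compound 3, `Fc1cccc(-c2nc(Nc3cccc(Br)c3)c3cc(F)ccc3n2)c1`: compound 3 gives only a limit of the assay, > 50000 nM.

Compound 3 stands at a limit of this assay, not at a number, and it is not alone there (the limit of > 50000 nM in this assay, at which 2 of the 3 values shown sit). The step of an at least 1.0-fold higher number from compound 1 to compound 2 (0.02 log units; that floor lies within the scatter) and the step of an at least 1.0-fold higher number from compound 1 to compound 3 (0.02 log units; that floor lies within the scatter) are each known only by a floor that lies within the scatter. The step that the two limits leave unreadable from compound 2 to compound 3 cannot be read, as both ends are limits.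

Compound 4, `Fc1cccc(-c2nc(Nc3ccccc3Br)c3cc(F)ccc3n2)c1`, differs from compound 3 by 2-bromophenyl in place of 3-bromophenyl on a nitrogen on an aromatic ring. Among the measured compounds shown here, the one measured step that exchanges one bromophenyl for another, from compound 2 to compound 3, is unreadable, and the step from compound 1 to compound 3 gives only a floor within the scatter. No step shown in this series moves a value clearly beyond the scatter, so the expected step from compound 3 to compound 4 is a step that the limit leaves unreadable from compound 3 to compound 4, none beyond the scatter. Compound 4 is therefore estimated at 60000 nM, within 20000 nM to 200000 nM, and most likely again reported only as a limit.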

Compound 4, half-maximal inhibitory concentration: > 50000 nM
Compound 4 ended at the assay's limit; the forecaster's own chance of this, stated with the estimate: 70%; the middle value does not contradict the limit.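

With 2-bromophenyl on the nitrogen, all three bromophenyl isomers shown, compound 2, compound 3 and compound 4, now share one limit, so none of the three placements of the bromine gives a number: the limit of > 50000 nM in this assay, at which 3 of the 4 values shown sit. The steps among these three compounds cannot be read, as both ends of each are limits. Among the compounds shown here, the only readable step is an at least 1.0-fold higher number from compound 1 to compound 4 (0.02 log units; that floor lies within the scatter), so even the 2-bromophenyl exchange is not separated from the 3-fluorophenyl of compound 1, the one compound with a number in this assay.

Whether the bromophenyl isomers differ at all stays hidden behind the limit. Also open, from the compounds shown here alone, is whether another group on that nitrogen, such as an aminophenyl or a carboxyphenyl, would give a value clearly beyond the scatter from compound 1.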